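A few compounds are considered here, and "the series" means these few. Any claim that something is new, unique, unknown or untested is made for them only; others in the source may bear on it.

Series notes. Three compounds carry numbers in a functional assay on HT-29 cells (Homo sapiens) for antiproliferative activity, read by sulforhodamine B assay, with a stated time of 48 h; a lower number here means a stronger inhibitor, a higher number a weaker inhibitor. Compound 1 `CCC(=O)Nc1ccc(S(=O)(=O)Oc2ccccc2C(C)C)cc1` gives 7400 nM. Compound 2 `CC(C)c1ccccc1OS(=O)(=O)c1ccc(NC(=O)CCl)cc1` gives 5600 nM, the step being a 1.3-fold lower number from compound 1 to compound 2 (0.12 log units; within the scatter). Compound 3 `O=C(CCl)Nc1ccc(S(=O)(=O)Oc2ccccc2I)cc1` gives 4100 nM, the step being a 1.4-fold lower number from compound 2 to compound 3 (0.14 log units; within the scatter). On the numbers shown compound 3 holds the lowest value of the three, but its distances to compound 2 and to compound 1 both lie within the scatter, so no ordering among the three can be claimed.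

Compound 4 `O=C(Nc1ccc(S(=O)(=O)Oc2ccccc2I)cc1)NC1CC1` is the next point: cyclopropylamino in place of chloromethyl on a carbonyl carbon. Written one bond further out, (chloromethyl)carbonyl becomes cyclopropylcarbamoyl, so the ((chloromethyl)carbonyl)amino of compound 3 becomes (cyclopropylcarbamoyl)amino.

For the measured compounds named here, no measured step replaces a chloromethyl by cyclopropylamino, so no direct precedent exists. The nearest measured step at the carbonyl carbon, a 1.3-fold lower number from compound 1 to compound 2 (0.12 log units; within the scatter), stayed within the scatter, and the step at the other end, a 1.4-fold lower number from compound 2 to compound 3 (0.14 log units; within the scatter), did the same. Both changes so far have moved the number little. The change in compound 4 is larger in what is counted, but nothing measured points in either direction, so the expected step is a 1.2-fold higher number from compound 3 to compound 4 (0.09 log units; within the scatter), none beyond the scatter, with a range widened for the untested change. Compound 4 is estimated at 5000 nM, within a range from 2000 nM to 15000 nM.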

Compound 4, half-maximal inhibitory concentration: 14000 nM
Compound 4: the middle estimate sits 2.8-fold (0.45 log units) below what was measured; the range from low to high includes it.
By their numbers in this assay, from the lowest: compounds 3, 2, 1 and 4 (each within the scatter of the next, the first and the last beyond it).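

In this assay, for the compounds shown here, cyclopropylamino in place of chloromethyl on a carbonyl carbon gives a 3.4-fold higher number from compound 3 to compound 4 (0.53 log units; beyond the scatter) and is the first step to lie beyond the scatter, so this carbonyl carbon is a place where the number can move towards a weaker inhibitor, which the earlier step at the same carbonyl carbon, a 1.3-fold lower number from compound 1 to compound 2 (0.12 log units; within the scatter), did not show. The change removes the chlorine and brings in a nitrogen with the hydrogen-bond donor and a three-membered ring all at once, and this single step cannot separate those parts. No measurement at hand bears on why the number rises with this change.

On these data alone, it remains open whether the rise follows the ring, the nitrogen or the loss of the chlorine: isopropylamino on the same carbonyl carbon would set the open chain against the ring, and cyclopropyl bound directly to that carbonyl carbon would test the ring without the nitrogen. Also open, as far as these compounds go, is whether the step keeps its size when isopropyl stands in place of iodo on the aromatic carbon.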